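Smaller aryl group on the ring nitrogen of compound 1

The source may report more compounds than this note shows. Statements on the series, on what has been measured and on what is new or still open speak of the compounds shown alone.

Compound 1 `O=C(NCCCCc1ccccc1)c1cccc(C2SCC(=O)N2c2ccc(-c3ccccc3)cc2)c1` carries a 4-phenylphenyl group on an amide-type nitrogen in a ring of the shared core. In a functional assay on HOS-TE85 cells (Homo sapiens) for inhibition, read by CCK-8 assay, with a stated time of 72 h (on this read-out higher numbers stand for weaker inhibition and lower numbers for stronger inhibition), compound 1 shows only a limit, > 1000 nM, and no number. Compound 2 `Cc1ccnc(N2C(=O)CS[C@@H]2c2cccc(C(=O)NCCCCn3cccn3)c2)c1` gives 21.9 nM in this assay, but compound 2 differs from compound 1 in more than one place, so the two values together show only that the series can reach strong inhibition while nothing links that to a single change. Compound 3 `COc1c(F)cccc1N1C(=O)CSC1c1cccc(C(=O)NCCCCc2ccccc2)c1` is not yet measured. 3-fluoro-2-methoxyphenyl in place of 4-phenylphenyl on an amide-type nitrogen in a ring Compound 1 stands at the limit of > 1000 nM in this assay, at which 1 of the 2 values shown sits, so the starting point of this step is itself only a bound. A step toward stronger inhibition is expected, an at least 3.3-fold lower number from compound 1 to compound 3 (0.52 log units; beyond the scatter), with uncertainty that is large on both sides. Compound 3 is expected to give about 300 nM in this assay, within a range from 60 nM to 3000 nM, and a further result at the limit remains possible.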

Compound 3, half-maximal inhibitory concentration: 26.2 nM
Beside the measured number, compound 3's estimate is 11-fold (1.06 log units) above it; measured number outside the range, below it.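

In this assay, for the compounds shown here, the replacement of 4-phenylphenyl by 3-fluoro-2-methoxyphenyl on the amide-type nitrogen gives the first comparison that can be read at a single place: an at least 38-fold lower number from compound 1 to compound 3 (1.58 log units; beyond the scatter). Everything else in the two structures is the same, so a change at this one position is enough to move the series from a limit to a measured number, and the 4-phenylphenyl group is not needed for strong inhibition with this phenylbutyl amide kept. The value of compound 1 is a limit and not a number, so the step is a lower bound and its true size stays unknown: the limit of > 1000 nM in this assay, at which 1 of the 3 values shown sits.

Going by these compounds alone, the entering group differs from the leaving one in several ways at once, with one aromatic ring in place of two plus a methoxy and a fluorine, and the single step does not separate these. Going by these compounds, how a plain phenyl, a phenyl carrying only the methoxy or only the fluorine, or a phenyl bearing an amine or a carboxylic acid would read at this position remains open.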